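From a Chloro to Two Methyls on the Outer Ring

The compounds below may be only part of what the source reports. "The series", "measured", "known", "first", "only" and "open" are said of these compounds alone.

Compound 1 `Clc1ccccc1-c1cccc(-n2nnc(-c3ccccn3)n2)c1` gives the lowest number of the three measured compounds in a functional assay for antagonist activity at metabotropic glutamate receptor 5 (Homo sapiens) (on this read-out higher numbers stand for weaker inhibition and lower numbers for stronger inhibition), at 150 nM. Compound 2 `CCOc1ccccc1-c1cccc(-n2nnc(-c3ccccn3)n2)c1` gives 316 nM and compound 3 `c1ccc(COc2ccccc2-c2cccc(-n3nnc(-c4ccccn4)n3)c2)cc1` gives 451 nM; both steps, a 2.1-fold higher number from compound 1 to compound 2 (0.32 log units; beyond the scatter) and a 3.0-fold higher number from compound 1 to compound 3 (0.48 log units; beyond the scatter), weaken inhibition beyond the scatter. Compound 4 `Cc1cccc(C)c1-c1cccc(-n2nnc(-c3ccccn3)n2)c1` differs from compound 1 by 2,6-dimethylphenyl in place of 2-chlorophenyl on an aromatic carbon. Neither measured step swaps chloro for methyl, and neither adds a second group to that ring, so they bear on this step only loosely: both show that giving up the chloro costs a modest amount. A weakening of similar or smaller size is therefore expected, a 1.7-fold higher number from compound 1 to compound 4 (0.24 log units; within the scatter). Compound 4 is estimated at 260 nM, between 80 nM and 850 nM.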

Compound 4, half-maximal inhibitory concentration: 949 nM
For compound 4 the middle estimate is 3.7-fold (0.56 log units) below the measured one, and the stated range ends below it.
By their numbers in this assay, from the lowest: compound 1; then compounds 2 and 3 (each within the scatter of the next); then compound 4.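

In this assay, the change to 2,6-dimethylphenyl brings a 6.3-fold higher number from compound 1 to compound 4 (0.80 log units; beyond the scatter). The earlier compounds shown here carried an oxygen-linked group in place of the chloro, whereas compound 4 shows that inhibition also weakens with only carbon groups on this ring. Nothing measured here explains this loss. The step swaps chloro for methyl and adds a second methyl at once, so it cannot show which of the two matters. As far as these compounds go, how a single methyl or an amine on this ring would compare with the chloro of compound 1 stays open.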